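Series notes: from compound 3 to compound 4

The source may report more compounds than this note shows. Statements on the series, on what has been measured and on what is new or still open speak of the compounds shown alone.

Compound 3 `COC(=O)[C@H](CCSC)NC(=O)c1ccc(NCc2cncn2Cc2cccc(Cl)c2)cc1-c1ccccc1` is known in a functional assay on NIH3T3 cells (Mus musculus) (a higher number here means that more compound is needed for the effect, a lower number that less compound is needed), only as a limit: compound 3 gives > 10 uM. Compound 1 `CSCC[C@H](NC(=O)c1ccc(NCc2cncn2Cc2cccc(Cl)c2)cc1-c1ccccc1)C(=O)O` likewise gives only a limit in this assay, > 10 uM. Compound 2 `N#Cc1ccc(Cn2cncc2CNc2ccc(C(=O)NCC3CCCCC3)c(-c3ccccc3)c2)cc1` gives only a limit as well, > 10 uM. Going by the values given here, the one step between measured compounds, a step that the two limits leave unreadable from compound 1 to compound 3, cannot be sized because of the limit of > 10 uM in this assay, at which 3 of the 3 values shown sit.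

Compound 4 `COC(=O)[C@H](CCSC)NC(=O)c1ccc(NCc2cncn2Cc2ccc(C)cc2)cc1-c1ccccc1` differs from compound 3 by 4-methylphenyl in place of 3-chlorophenyl on a saturated chain carbon bound to an aromatic nitrogen. Among the compounds with values here, no measured step touches this change, and no measured step in this assay has a readable size, so no measured evidence points to compound 4 coming into the readable range. Compound 4 is therefore expected to stay at the limit, the step that the limit leaves unreadable from compound 3 to compound 4 being expected to remain unreadable. The estimate for compound 4 is 20 uM, within 5 uM to 80 uM.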

Compound 4, concentration for half-maximal effect: > 10 uM
Compound 4: only a limit was reported (the forecaster's own chance of this, stated with the estimate: 80%); the middle value does not contradict the limit.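

Going by these compounds alone, no step from compound 3 to compound 4 can be read, as both are known only as limits: the limit of > 10 uM in this assay, at which 4 of the 4 values shown sit. The compounds shown leave open how 4-methylphenyl compares with 3-chlorophenyl, and which change to the shared core would give a readable value.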